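Oxanylmethyl for cyclohexyl on the imidazole carbon of compound 3

The source may hold more compounds than are shown below. What is called first, only, known or untested is meant among the compounds shown, and "the series" means these compounds.

Measured compounds:
Compound 1 `O=C(O)c1ccccc1-c1ccc(CCc2ncc(CC3CCCCC3)[nH]2)cc1`: 41 nM
Compound 2 `CCCCc1cnc(Cc2ccc(-c3ccccc3C(=O)O)cc2)[nH]1`: > 10000 nM
Compound 3 `O=C(O)c1ccccc1-c1ccc(CCc2ncc(C3CCCCC3)[nH]2)cc1`: 375 nM

In an in vitro functional assay on cells for agonist activity at Bombesin receptor subtype-3 (Homo sapiens), read by luminescence and calcium flux (on this read-out lower numbers stand for an effect already at smaller amounts and higher numbers for an effect only at larger amounts of compound), compound 3 gives 375 nM, the highest of the two numbers recorded there. Compound 1 gives 41 nM in this assay. For compound 2 this assay reports only a limit, > 10000 nM, not a number (the limit of > 10000 nM in this assay, at which 1 of the 3 values shown sits). Among the compounds with values here, the one measured step that bears on the present change is a 9.1-fold higher number from compound 1 to compound 3 (0.96 log units; beyond the scatter).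

Compound 4 `O=C(O)c1ccccc1-c1ccc(CCc2ncc(CC3CCOCC3)[nH]2)cc1` differs from compound 3 in one place: (oxan-4-yl)methyl in place of cyclohexyl on an aromatic carbon. The change therefore restores a methylene between the aromatic carbon and the six-membered ring, as in compound 1, but the ring now carries an oxygen. The step from compound 1 to compound 3 shows that removing that methylene raised the number well beyond the scatter; putting it back is expected to move the number in the other direction. How the ring oxygen shifts the result is not shown by any measured pair here, so the estimate stays between compound 3 and compound 1. Compound 4 is expected to give 150 nM in this assay, within 30 nM to 1000 nM, an expected step of a 2.5-fold lower number from compound 3 to compound 4 (0.40 log units; beyond the scatter).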

Compound 4, half-maximal effective concentration: 338 nM
Compound 4: middle estimate off by 2.3-fold (0.35 log units), on the low side; low and high end bracket the measured number.
By their numbers in this assay, from the lowest: compound 1; then compounds 4 and 3 (each within the scatter of the next). At a limit, above all of these: compound 2.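

With the methylene kept in place in this assay, oxan-4-yl in place of cyclohexyl on the saturated chain carbon gives an 8.2-fold higher number from compound 1 to compound 4 (0.92 log units; beyond the scatter) and so separates two rings that differ only in a ring oxygen. The direct exchange on the aromatic carbon gives a 1.1-fold lower number from compound 3 to compound 4 (0.05 log units; within the scatter) in this assay, so cyclohexyl and (oxan-4-yl)methyl cannot be told apart at this position. A methylene on the aromatic carbon therefore does not by itself bring back the value of compound 1 (41 nM) once the ring carries an oxygen, a point that the earlier step, a 9.1-fold higher number from compound 1 to compound 3 (0.96 log units; beyond the scatter) on removing the methylene, could not show.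

Going by these compounds, it remains open whether a nitrogen in the same ring, as in a piperidine, or a fluorine on the cyclohexane ring would behave like the oxygen or like the carbon it replaces. Nothing given here bears on the reason for these steps.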